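Methoxy in Place of Fluoro: Expecting Compound 4

A few compounds are considered here, and "the series" means these few. Any claim that something is new, unique, unknown or untested is made for them only; others in the source may bear on it.

The measured compounds:
- Compound 1, `CC(C)N1C(=O)COc2ccc(-c3cccc(NS(=O)(=O)c4ccc(F)cc4)c3)cc21`, gives 22600 nM in a functional assay on HCT-116 cells (Homo sapiens) for antiproliferative activity, read by MTT assay, with a stated time of 72 h; a lower number here means a stronger inhibitor, a higher number a weaker inhibitor.
- Compound 2, `O=C1COc2ccc(-c3cccc(NS(=O)(=O)c4ccc(F)cc4)c3)cc2N1c1ccc(Cl)cc1`, gives 23900 nM in this assay.
- Compound 3, `O=C1COc2ccc(-c3cccc(NS(=O)(=O)c4ccc(F)cc4)c3)cc2N1c1ccc(F)cc1`, is reported in this assay only as a limit, > 40000 nM.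

Compound 3 thus stands at the edge of what this assay can report, namely (the limit of > 40000 nM in this assay, at which 1 of the 3 values shown sits), and no exact number is known for it. Compound 1 and compound 2 both give numbers that the scatter does not separate, and the steps of a 1.1-fold higher number from compound 1 to compound 2 (0.02 log units; within the scatter) and an at least 1.7-fold higher number from compound 1 to compound 3 (0.24 log units; that floor lies within the scatter) stay within it.

Compound 4, `COc1ccc(N2C(=O)COc3ccc(-c4cccc(NS(=O)(=O)c5ccc(F)cc5)c4)cc32)cc1`, differs from compound 3 by methoxy in place of fluoro on an aromatic carbon. For the measured compounds named here, the only measured step touching the same position is an at least 1.6-fold higher number from compound 2 to compound 3 (0.22 log units; that floor lies within the scatter), which reads as a floor within the scatter. Going by the values given here, none of the measured steps involves a methoxy group, so there is no direct precedent for the change here. Taken together, the steps show this part of the molecule has moved this assay little, and no step beyond the scatter is expected from compound 3 to compound 4 either.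

For compound 4 the expected value in this assay is 40000 nM, within a range from 18000 nM to 90000 nM, and the step of a number no higher from compound 3 to compound 4 (the limit leaves the size open) is estimated to be small.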

Compound 4, half-maximal inhibitory concentration: 28300 nM
Compound 4: the middle estimate sits 1.4-fold (0.15 log units) above what was measured, and the stated range covers the measured number.
By their numbers in this assay, from the lowest: compounds 1, 2 and 4 (each within the scatter of the next). At a limit, above all of these: compound 3.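

Compound 4 puts an exact number on a 4-substituted phenyl group where the 4-fluorophenyl of compound 3 gave none. Compound 3 remains a limit and not a number, and the comparison with it gives only a floor: the limit of > 40000 nM in this assay, at which 1 of the 4 values shown sits.

Against that limit, the change in this assay reads as an at least 1.4-fold lower number from compound 3 to compound 4 (0.15 log units; that floor lies within the scatter), and how far apart the two compounds truly lie cannot be read. The other two comparisons are a 1.2-fold higher number from compound 2 to compound 4 (0.07 log units; within the scatter) and a 1.3-fold higher number from compound 1 to compound 4 (0.10 log units; within the scatter), so methoxy, chloro and the isopropyl swap on the ring nitrogen all give numbers that the scatter does not separate, with only compound 3 unplaced among them.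

From the compounds shown here alone, it stays open whether an amine or a carboxylic acid on this phenyl ring, or a longer chain on the ring nitrogen in place of isopropyl, would shift the number beyond the scatter. Going by these compounds, the rest of the molecule is the same in all four compounds, so what changes there would do to the number also remains unknown.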